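The source may hold more compounds than are shown below. What is called first, only, known or untested is meant among the compounds shown, and "the series" means these compounds.

Series notes on a functional assay on MKN-74 cells (Homo sapiens) for antiproliferative activity, with a stated time of 24 h; on this read-out higher numbers stand for weaker inhibition and lower numbers for stronger inhibition. Three compounds share one core. Compound 1 `NC(=O)c1c(NC(=O)c2ccc(C(F)(F)F)cc2)sc2c1CCN(Cc1ccc(Cl)cc1Cl)C2` gives 10900 nM, compound 2 `NC(=O)c1c(NC(=O)c2ccccc2F)sc2c1CCN(Cc1c(Cl)cccc1Cl)C2` gives 7430 nM, and compound 3 `NC(=O)c1c(NC(=O)c2ccccc2F)sc2c1CCN(Cc1ccc(Cl)cc1Cl)C2` gives 9610 nM. Compound 3 therefore sits between the other two numbers, but neither neighbour separates from it: the step of a 1.1-fold lower number from compound 1 to compound 3 (0.05 log units; within the scatter) and the step of a 1.3-fold higher number from compound 2 to compound 3 (0.11 log units; within the scatter) both lie within the scatter, so the three numbers read as one level.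

Next step under consideration: compound 4 `NC(=O)c1c(NC(=O)c2cccc([N+](=O)[O-])c2)sc2c1CCN(Cc1ccc(Cl)cc1Cl)C2`. The change from compound 3 is 3-nitrophenyl in place of 2-fluorophenyl on a carbonyl carbon. Among the compounds with values here, the only measured step that bears on it is the earlier swap on the same carbonyl carbon, a 1.1-fold lower number from compound 1 to compound 3 (0.05 log units; within the scatter), which brought no movement beyond the scatter. Nothing else in the set touches that position. Taken on that one step, no movement beyond the scatter is expected in this assay for compound 4, and the estimated step is a 1.0-fold higher number from compound 3 to compound 4 (0.02 log units; within the scatter). Compound 4 is thus expected to give about 10000 nM, within a range of 4000 nM to 25000 nM.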

Compound 4, half-maximal inhibitory concentration: 16500 nM
The estimate for compound 4 lay 1.7-fold (0.22 log units) below the measured number; the measured number falls inside the stated range.
By their numbers in this assay, from the lowest: compounds 2, 3, 1 and 4 (each within the scatter of the next, the first and the last beyond it).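

In this assay the carbonyl carbon now carries a third aryl group with the 2,4-dichlorophenyl group held fixed, and both new steps stay within the scatter: a 1.7-fold higher number from compound 3 to compound 4 (0.23 log units; within the scatter) and also a 1.5-fold higher number from compound 1 to compound 4 (0.18 log units; within the scatter) so 3-nitrophenyl, 2-fluorophenyl and 4-(trifluoromethyl)phenyl read as one level at this position. The change from 2-fluorophenyl to 3-nitrophenyl also takes the hydrogen-bond acceptor count of the group from 0 to 2, with no step beyond the scatter in this read-out. No independent measurement bears on this result.

The compounds shown leave open whether an aminophenyl group, a carboxyphenyl group or a saturated alkyl chain on the same carbonyl carbon would move the number beyond the scatter. Also open, from the compounds shown here alone, is whether these aryl groups stay at one level with the 2,6-dichlorophenyl group of compound 2 in place of 2,4-dichlorophenyl.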